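A thiourea in place of the nitrobenzyl group

This account rests on a few compounds, and the source may have more. Where it says the series, first, only, none or still open, it means among the compounds named here.

Compound 1 `NC(=O)c1c(NC(=O)c2ccccc2Cl)sc2c1CCN(Cc1ccc([N+](=O)[O-])cc1)C2` gives 46100 nM. Compound 2 `NC(=O)c1c(NC(=O)c2ccc(C(F)(F)F)cc2)sc2c1CCN(Cc1ccccc1F)C2` gives > 50000 nM, a limit of the assay and not a number. Compound 3 `NC(=O)c1c(NC(=O)c2ccccc2Cl)sc2c1CCN(C(=S)Nc1ccc(C(F)(F)F)cc1)C2` gives > 50000 nM, also a limit.

Among the compounds with values here, in a functional assay on HeLa cells (Homo sapiens) for antiproliferative activity, with a stated time of 24 h (a lower number here means a stronger inhibitor, a higher number a weaker inhibitor), compound 1 stands as the only actual number among the three results, and it is a weak one. The other two results sit at the limit of > 50000 nM in this assay, at which 2 of the 3 values shown sit. Compound 4 `NC(=O)c1c(NC(=O)c2ccccc2Cl)sc2c1CCN(C(=S)Nc1c(Cl)cccc1Cl)C2` differs from compound 1 by a group of 11 heavy atoms (7 carbon, 1 nitrogen, 1 sulfur, 2 chlorine; one six-membered aromatic ring of carbon only) in place of a group of 10 heavy atoms (7 carbon, 1 nitrogen, 2 oxygen; one six-membered aromatic ring of carbon only), on an amine nitrogen in a ring. Within the data shown here, no step between two measured compounds is available, so the expectation rests on compound 1 alone and on (the limit of > 50000 nM in this assay, at which 2 of the 3 values shown sit). The step from compound 1 to compound 4 is expected to be a 1.2-fold higher number from compound 1 to compound 4 (0.08 log units; within the scatter), a small weakening, with the limit a likely outcome. Compound 4 is estimated at 55000 nM, within 20000 nM to 150000 nM.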

Compound 4, half-maximal inhibitory concentration: 26500 nM
For compound 4 the middle estimate is 2.1-fold (0.32 log units) above the measured one, and the stated range covers the measured number.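

On the amine nitrogen in a ring, the thiourea group of compound 4 can replace 4-nitrobenzyl and still give a measured number, with a 1.7-fold lower number from compound 1 to compound 4 (0.24 log units; within the scatter) in this assay. The result for compound 3 is a limit of the assay and not a number. As far as these compounds go, with 2,6-dichlorophenyl in place of 4-(trifluoromethyl)phenyl on the amide-type nitrogen, the thiourea series shows an at least 1.8-fold lower number from compound 3 to compound 4 (0.27 log units; that floor lies within the scatter), so the true size of this step is unknown. Still open, from the compounds shown here alone, is whether a urea in place of the thiourea, or a carboxylic acid on its phenyl ring, would give a clearly lower number.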